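This account rests on a few compounds, and the source may have more. Where it says the series, first, only, none or still open, it means among the compounds named here.

In a functional assay on MCF7 cells (Homo sapiens) for cytotoxicity, read by MTT assay, with a stated time of 72 h (on this read-out higher numbers stand for weaker inhibition and lower numbers for stronger inhibition), compound 1 (`COc1cc2ncnc(Nc3ccc(F)c(Cl)c3)c2cc1NC(=O)/C=C/c1ccc(F)cc1Cl`) is reported as "not active" (no number reported), without a number. Compound 2 (`COc1ccc(OC)c(/C=C/C(=O)Nc2cc3c(Nc4ccc(F)c(Cl)c4)ncnc3cc2OC)c1`) gives 34300 nM, and compound 3 (`COc1ccc(/C=C/C(=O)Nc2cc3c(Nc4ccc(F)c(Cl)c4)ncnc3cc2OC)c(OC)c1`) gives 36600 nM. Among the measured compounds shown here, compound 3 therefore stands level with compound 2, as the only measured step is a 1.1-fold higher number from compound 2 to compound 3 (0.03 log units; within the scatter). That step exchanged 2,5-dimethoxyphenyl for 2,4-dimethoxyphenyl.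

Compound 4 (`COc1cc2ncnc(Nc3ccc(F)c(Cl)c3)c2cc1NC(=O)/C=C/c1cc(OC)c(OC)c(OC)c1`) departs from compound 3 in one place, on a double-bonded chain carbon bound to a double-bonded chain carbon: 3,4,5-trimethoxyphenyl in place of 2,4-dimethoxyphenyl on a double-bonded chain carbon bound to a double-bonded chain carbon. The step between the two dimethoxyphenyl compounds is the nearest guide, but it says little about a 3,4,5-trimethoxyphenyl group. Compound 1, at "not active" (no number reported), shows that a compound of this set can also yield no number in this assay, so that outcome remains possible. No step beyond the scatter is expected, and no direction is favoured. The expected step is a 1.1-fold lower number from compound 3 to compound 4 (0.04 log units; within the scatter). The estimate for compound 4 is 33000 nM, with an expected range from 13000 nM to 80000 nM.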

Compound 4, half-maximal inhibitory concentration: "not active" (no number reported)
For compound 4 the study gives words and no number; there is nothing to compare the estimate with.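

In this assay, among the compounds shown here, compound 4 is reported as "not active" (no number reported) and no new step can therefore be read against compound 3 or any other compound. Nothing measured here bears on this result. The compounds shown leave open whether compound 1 and compound 4 have any activity at higher concentrations.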